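The source may report more compounds than this note shows. Statements on the series, on what has been measured and on what is new or still open speak of the compounds shown alone.

Compound 1 `CC(=O)/C(=N\Nc1ccccc1)N(C)c1cccc(Cl)c1` and compound 2 `CC(=O)/C(=N\Nc1ccccc1Cl)N(C)c1cccc(Cl)c1` share one core, while compound 3 `CC(=O)/C(=N\c1ccccc1)NNc1ccccc1C(F)(F)F` is built on another, and the difference between the two cores is not broken down here. In an assay on isolated protein for binding affinity to corticotropin-releasing factor receptor 1 (Homo sapiens) (a lower number here means a stronger inhibitor, a higher number a weaker inhibitor), compound 1 gives only a limit, > 10000 nM. Compound 2 likewise gives only a limit in this assay, > 10000 nM. The change from compound 1 to compound 2 is chloro in place of hydrogen on an aromatic carbon. Its step, a step that the two limits leave unreadable from compound 1 to compound 2, is unreadable because of the limit of > 10000 nM in this assay, at which 2 of the 3 values shown sit. For the measured compounds named here, compound 3 is the one compound with a number: in this assay compound 3 gives 2260 nM. Compound 4 `CC(=O)/C(=N\c1ccccc1Cl)NNc1ccccc1C(F)(F)F` has not yet been measured; it differs from compound 3 by chloro in place of hydrogen on an aromatic carbon, the same change as that from compound 1 to compound 2. Since that earlier step has no readable size, the expectation for compound 4 rests on compound 3 alone, whose value 2260 nM serves as the anchor, with the change allowed to move it modestly either way. Compound 4 is therefore expected to land near 1500 nM, between 400 nM and 6000 nM, an estimated step of a 1.5-fold lower number from compound 3 to compound 4 (0.18 log units; within the scatter).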

Compound 4, inhibition constant: > 10000 nM
Compound 4: only a limit was reported (the forecaster's own chance of this, stated with the estimate: 15%); middle value at least 6.6-fold (0.82 log units) away from the limit.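

On the core of compound 3, chloro in place of hydrogen on an aromatic carbon, here phenyl to 2-chlorophenyl, brings an at least 4.4-fold higher number from compound 3 to compound 4 (0.64 log units; beyond the scatter). On these data alone, compound 4 gives only a limit in this assay, > 10000 nM, so the step has a lower bound and its full size stays unknown. The same change on the other core, from compound 1 to compound 2, cannot be read, and so the series does not show whether the change carries from one core to the other, only that on the core of compound 3 it goes with a higher number: the limit of > 10000 nM in this assay, at which 3 of the 4 values shown sit.

The compounds shown leave open how a methoxy group or an amine would fare in place of the chloro on the core of compound 3. They also leave open whether any compound on the core of compound 1 would give a number in this assay, which a comparison of this change across the two cores would need.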